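A Tetrazolyl Sulfanyl Group Enters the Chain

The source may hold more compounds than are shown below. What is called first, only, known or untested is meant among the compounds shown, and "the series" means these compounds.

In a functional assay on Coronary artery (Bos taurus) (a higher number here means that more compound is needed for the effect, a lower number that less compound is needed), compound 1 `CCCCCCC(=O)N(CCCC/C=C\CCCCCCC(=O)OCCOCCOCCO)C(C)C` gives 2900 nM and compound 2 `CCCCCNC(=O)NCCCC/C=C\CCCCCNS(=O)(=O)c1ccccc1` gives 3400 nM while compound 3 `CCCCCNC(=O)NCCCC/C=C\CCCCCS(=O)(=O)c1ccccc1O` gives 5000 nM on the same scale. All three numbers lie within the usual scatter of one another, so compound 3 stands level with the other two and cannot be ranked against them.

Compound 4 `CCCCCNC(=O)NCCCC/C=C\CCCCCSc1nnn[nH]1` differs from compound 3 in one place, and (1H-tetrazol-5-yl)sulfanyl in place of (2-hydroxyphenyl)sulfonyl on a saturated chain carbon, five bonds along the chain from a double-bonded chain carbon sums up the exchange: (1H-tetrazol-5-yl)sulfanyl in place of (2-hydroxyphenyl)sulfonyl on a saturated chain carbon, five bonds along the chain from a double-bonded chain carbon.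

Among the compounds with values here, the only measured step at that place is a 1.5-fold higher number from compound 2 to compound 3 (0.17 log units; within the scatter) and it swapped one group for another without moving the number beyond the scatter. Within the data shown here, no measured compound carries a tetrazole, so this single small step is a thin guide and the uncertainty stays wide. With nothing pointing clearly either way, no step beyond the scatter is expected in this assay and the estimated change is a 1.7-fold lower number from compound 3 to compound 4 (0.22 log units; within the scatter) at its middle. For compound 4 the estimated value is 3000 nM with an expected range from 600 nM to 12000 nM across repeated measurements.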

Compound 4, half-maximal effective concentration: 3700 nM
Beside the measured number, compound 4's estimate is 1.2-fold (0.09 log units) below it; measured number inside the range.
By their numbers in this assay, from the lowest: compounds 1, 2, 4 and 3 (each within the scatter of the next).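

At this saturated chain carbon, five bonds along the chain from a double-bonded chain carbon, a much larger exchange of group than the earlier step still leaves the number in this assay within the scatter: the exchange gives a 1.4-fold lower number from compound 3 to compound 4 (0.13 log units; within the scatter), and measured against the (phenylsulfonyl)amino group it gives a 1.1-fold higher number from compound 2 to compound 4 (0.04 log units; within the scatter). The entering (1H-tetrazol-5-yl)sulfanyl has 6 heavy atoms and a five-membered aromatic ring with 4 hetero atoms, whereas the leaving (2-hydroxyphenyl)sulfonyl has 10 heavy atoms and a six-membered aromatic ring of carbon only, so at this place neither ring type nor group size shows any readable effect on the number among these compounds. No supporting measurement is available to explain this flat result.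

From the compounds shown here alone, whether any group at this place can move the number beyond the scatter remains open, since every step read here stays within it. A carboxylic acid or an amine on the same carbon, or a longer chain carrying the tetrazole, would test whether this end of the molecule matters in this assay at all.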